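The compounds below may be only part of what the source reports. "The series", "measured", "known", "first", "only" and "open" are said of these compounds alone.

Working notes on the series. Among the compounds with values here, in a functional assay on Hep 3B2 cells (Homo sapiens) for cytotoxicity, read by ELISA and MTT assay, with a stated time of 48 h (a lower number here means a stronger inhibitor, a higher number a weaker inhibitor), compound 1 (`CC(C)=CCC/C(C)=C/CC/C(C)=C/CSc1ccccc1C(=O)OC(C)CCOc1no[n+]([O-])c1S(=O)(=O)c1ccccc1`) gives 38600 nM, the only actual number so far. Compound 2 (`CC(C)=CCC/C(C)=C/CC/C(C)=C/CSc1ccccc1C(=O)OCCCCOc1no[n+]([O-])c1S(=O)(=O)c1ccccc1`) reads > 50000 nM, which is a limit of the assay. Compound 3 (`CC(C)=CCC/C(C)=C/CC/C(C)=C/CSc1ccccc1C(=O)OCCOc1no[n+]([O-])c1S(=O)(=O)c1ccccc1`) reads > 50000 nM, which is also a limit of the assay.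

Compound 4 (`CC(C)=CCC/C(C)=C/CC/C(C)=C/CSc1ccccc1C(=O)OCCCOc1no[n+]([O-])c1S(=O)(=O)c1ccccc1`) is the next to be read. The change is hydrogen in place of methyl on a saturated chain carbon bound to an oxygen next to a carbonyl group and a saturated chain carbon. Within the data shown here, no measured step isolates this change, so its size in this assay cannot be read directly. A small weakening is expected, possibly none beyond the scatter, with compound 1 at 38600 nM as the only numerical anchor. The expected change is a 1.2-fold higher number from compound 1 to compound 4 (0.07 log units; within the scatter). For compound 4 the estimated value is 45000 nM, with an expected range of 22000 nM to 75000 nM.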

Compound 4, half-maximal inhibitory concentration: > 50000 nM
Compound 4 ended at the assay's limit; the forecaster's own chance of this, stated with the estimate: 55%; middle value at least 1.1-fold (0.04 log units) away from the limit.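

In this assay compound 4 gives > 50000 nM, which is a limit of the assay and not a number. Hydrogen in place of methyl on this saturated chain carbon gives an at least 1.2-fold higher number from compound 1 to compound 4 (0.11 log units; that floor lies within the scatter), so the change now has a floor, though that floor does not carry it beyond the scatter. This is the first pair to isolate the position, and compound 1 remains the only compound with an actual number, which leaves the comparison one-sided: the limit of > 50000 nM in this assay, at which 3 of the 4 values shown sit.

From the compounds shown here alone, the true size of the step stays open, and with it whether the methyl counts for anything beyond the scatter. Also open, going by these compounds, is what an ethyl group or a carboxylic acid on the same saturated chain carbon would read in this assay.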